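A few compounds are considered here, and "the series" means these few. Any claim that something is new, unique, unknown or untested is made for them only; others in the source may bear on it.

Compound 1 `CCSC(=S)SCC(=O)c1ccc(C)cc1` and compound 2 `Cc1ccc(C(=O)CSC(=S)SC(C)C)cc1` share one core; compound 3 `CC(C)SC(=S)SCC(=O)c1ccc(Cl)c(Cl)c1` carries a second core, and compound 4 `CCSC(=S)SCC(=O)c1ccc(Cl)c(Cl)c1` is its unmeasured counterpart. In a functional assay on HeLa cells (Homo sapiens) for antiproliferative activity, read by resazurin assay (on this read-out lower numbers stand for stronger inhibition and higher numbers for weaker inhibition), compound 1 gives 3980 nM, compound 2 gives 25100 nM, and compound 3 gives 25100 nM. The change from compound 2 to compound 1 is hydrogen in place of methyl on a saturated chain carbon bound to a saturated chain carbon and a sulfur, and it made a 6.3-fold lower number from compound 2 to compound 1 (0.80 log units; beyond the scatter). How the two cores differ is not broken down here. The same change, (hydrogen in place of methyl on a saturated chain carbon bound to a saturated chain carbon and a sulfur), is made from compound 3 to compound 4. Because the step of a 6.3-fold lower number from compound 2 to compound 1 (0.80 log units; beyond the scatter) lies beyond the scatter, a lowering is expected for compound 4, though it rests on a single step seen on the other core, so a somewhat smaller step a 4.0-fold lower number from compound 3 to compound 4 (0.60 log units; beyond the scatter) is estimated. Compound 4 is expected to give about 6300 nM, between 2500 nM and 16000 nM.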

Compound 4, half-maximal inhibitory concentration: 7940 nM
For compound 4 the middle estimate is 1.3-fold (0.10 log units) below the measured one; low and high end bracket the measured number.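

In this assay, replacing isopropyl with ethyl on the second core gave a 3.2-fold lower number from compound 3 to compound 4 (0.50 log units; beyond the scatter), a lowering in the same direction as on the first core. The two steps cannot be told apart: the same change on two cores in this assay, a 6.3-fold lower number (0.80 log units; beyond the scatter) from compound 2 to compound 1 and a 3.2-fold lower number (0.50 log units; beyond the scatter) from compound 3 to compound 4, 2.0-fold (0.30 log units) apart, within the scatter of two such steps. For the compounds shown here, the change therefore carried over between these two cores, but this rests on only two pairs in one assay and does not show that it would hold on any other core.

The compounds shown leave open how butylsulfanyl, a longer chain, or benzylsulfanyl would compare with ethylsulfanyl. They also leave open whether a carboxylic acid on the chain would be tolerated on either core.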